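Flipping One Ring Stereocentre in a Hydroxamic Acid Series

The source may hold more compounds than are shown below. What is called first, only, known or untested is meant among the compounds shown, and "the series" means these compounds.

Measured so far:
Compound 1, `O=C(NO)c1cccc(-c2cn([C@@H]3C[C@@H](CO)N(Cc4ccccc4)C3)nn2)c1`: < 10%
Compound 2, `O=C(NO)c1cccc(-c2cn([C@H]3C[C@@H](C(=O)O)N(Cc4ccccc4)C3)nn2)c1`: 14%

In an assay on Sf9 cells for inhibition of histone deacetylase 11 (Homo sapiens), read by fluorescence, tested at 0.5 uM (on this read-out higher numbers stand for more inhibition at the one concentration tested (going by the name of the read-out) and lower numbers for less inhibition), compound 1 gives only a limit, < 10%. In this assay, going by the values given here, compound 2 gives 14%, the only actual number among the two, since the other value is the limit of < 10% in this assay, at which 1 of the 2 values shown sits. Compound 3, `O=C(NO)c1cccc(-c2cn([C@@H]3C[C@@H](C(=O)O)N(Cc4ccccc4)C3)nn2)c1`, is not yet measured. Its change from compound 2 is small: the two compounds have the same atoms and bonds and differ only in configuration as drawn: 1 of 2 stereo elements differ; a stereocentre at a saturated ring carbon is drawn S in compound 2 and R in compound 3. Among the compounds with values here, no measured step guides this change, so no shift beyond the usual scatter is expected in either direction. Compound 3 is therefore expected to give about 12%, between 0% and 25%, a step of a number 2 percentage points lower from compound 2 to compound 3 (within the scatter) expected to stay within scatter.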

Compound 3, a percentage reported as inhibition, at one concentration (the size of the read-out at that concentration, not a potency): < 10%
Compound 3: only a limit was reported; the forecaster's own chance of this, stated with the estimate: 40%; at least 2 percentage points between middle value and limit.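

Going by these compounds alone, this is the first measured step at the saturated ring carbon: in this assay, redrawing its stereocentre from S to R gives a number at least 4 percentage points lower from compound 2 to compound 3 (that floor lies within the scatter). That step cannot show that the configuration at this position matters for the compounds carrying carboxy. Compound 3 gives only a limit: the limit of < 10% in this assay, at which 2 of the 3 values shown sit.

The step between the two limits cannot be read, so the swap of carboxy for hydroxymethyl stays unresolved. On these data alone, whether an amine or a primary amide on this ring carbon would change inhibition, in either configuration, remains open.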